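Swapping tert-butyl for cyclohexyl on the benzoyl group

The source may hold more compounds than are shown below. What is called first, only, known or untested is meant among the compounds shown, and "the series" means these compounds.

Measured so far:
compound 1 `CC(C)(C)c1ccc(C(=O)N2CCC3(CC2)C(=O)N(CC(=O)N2CCC(CCO)CC2)CN3c2ccccc2)cc1` gives 2600 nM
compound 2 `CC(C)(C)OC(=O)NC1CCN(C(=O)CN2CN(c3ccccc3)C3(CCN(C(=O)c4ccc(C(C)(C)C)cc4)CC3)C2=O)CC1` gives 8300 nM
compound 3 `CC(C)(C)c1ccc(C(=O)N2CCC3(CC2)C(=O)N(CC(=O)NCCN)CN3c2ccccc2)cc1` gives 7000 nM

These three compounds share one core and were compared in an assay on HEK293 cells for displacement of a labelled ligand from NPC1-like intracellular cholesterol transporter 1 (Homo sapiens); on this read-out lower numbers stand for stronger inhibition and higher numbers for weaker inhibition. Compound 2 has the highest number of the three: its step from compound 1, a 3.2-fold higher number from compound 1 to compound 2 (0.50 log units; beyond the scatter), lies beyond the scatter, while its gap to compound 3 falls within it, so no order between compound 2 and compound 3 can be claimed.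

Compound 4 `CC(C)(C)OC(=O)NC1CCN(C(=O)CN2CN(c3ccccc3)C3(CCN(C(=O)c4ccc(C5CCCCC5)cc4)CC3)C2=O)CC1` differs from compound 2 in one place: cyclohexyl in place of tert-butyl on an aromatic carbon. Neither measured step bears on this change. The steps of a 3.2-fold higher number from compound 1 to compound 2 (0.50 log units; beyond the scatter) and a 2.7-fold higher number from compound 1 to compound 3 (0.43 log units; beyond the scatter) both concern the far end of the molecule, the group attached through the carbonyl, and the 4-(tert-butyl)phenyl part is the same in compound 1, compound 2 and compound 3. Nothing in these data therefore shows how this assay responds to a change there, and the expectation for compound 4 is a step of about a 1.0-fold lower number from compound 2 to compound 4 (0.02 log units; within the scatter), that is, no step beyond the scatter, with a wide range. Compound 4 is thus estimated at 8000 nM, between 2500 nM and 25000 nM.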

Compound 4, half-maximal inhibitory concentration: 4800 nM
Estimate against measurement, compound 4: 1.7-fold (0.22 log units) above, and the stated range covers the measured number.
By their numbers in this assay, from the lowest: compounds 1, 4, 3 and 2 (each within the scatter of the next, the first and the last beyond it).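

In this assay, going by these compounds alone, this is the first reading at the far side of the benzoyl group, and replacing tert-butyl with cyclohexyl gives a 1.7-fold lower number from compound 2 to compound 4 (0.24 log units; within the scatter) on the aromatic carbon. The two compounds therefore cannot be told apart, even though cyclohexyl adds a six-membered non-aromatic ring of carbon only where tert-butyl has no ring. With the far end of compound 2 held constant, this position accepts either group without a change beyond the scatter, and no measurement here offers an explanation for that result.

As far as these compounds go, it remains open whether cyclohexyl gives a similar reading alongside the 2-hydroxyethyl group of compound 1. It is also unknown whether an amine or a carboxylic acid on this aromatic carbon would move the number beyond the scatter.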